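Trifluoromethyl in place of 2-fluorophenyl on the shared core

The source may hold more compounds than are shown below. What is called first, only, known or untested is meant among the compounds shown, and "the series" means these compounds.

Three compounds of the series have numbers in an ADME assay on the whole organism (Mus musculus, strain Swiss Webster) for pharmacokinetics, read by LC-MS, at a dose of 50 mg/kg by the oral route; on this read-out lower numbers stand for lower exposure and higher numbers for higher exposure at the dose given. Compound 1 `O=C(Nc1ccc(F)c(-c2nc3ncc(-c4ccccc4F)cc3[nH]2)c1)N1CCCC1` gives 4870 ng.h/mL in this assay, the second highest of the three. Compound 3 `O=C(Nc1ccc(F)c(-c2nc3ncc(-c4cccc(F)c4F)cc3[nH]2)c1)N1CCCC1` gives 4750 ng.h/mL, and the step of a 1.0-fold lower number from compound 1 to compound 3 (0.01 log units; within the scatter) lies within the scatter. Going by the values given here, compound 2 `O=C(Nc1ccc(F)c(-c2nc3ncc(-c4cccnc4F)cc3[nH]2)c1)N1CCCC1` gives 30900 ng.h/mL, the step of a 6.3-fold higher number from compound 1 to compound 2 (0.80 log units; beyond the scatter) being the only change from compound 1 that moved the number beyond the scatter; the step of a 6.5-fold lower number from compound 2 to compound 3 (0.81 log units; beyond the scatter) runs back the other way.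

Compound 4 `O=C(Nc1ccc(F)c(-c2nc3ncc(C(F)(F)F)cc3[nH]2)c1)N1CCCC1` differs from compound 1 as follows: trifluoromethyl in place of 2-fluorophenyl on an aromatic carbon. Among the compounds with values here, none of the measured steps removes the aromatic ring at this position; the steps from compound 1 only alter a substituent on that ring or exchange it for another six-membered aromatic ring, so no measured step bears directly on this change. Within the data shown here, the only step that was beyond the scatter, a 6.3-fold higher number from compound 1 to compound 2 (0.80 log units; beyond the scatter), went upward. Compound 4 is therefore expected to give a step of a 1.3-fold higher number from compound 1 to compound 4 (0.13 log units; within the scatter), with the direction uncertain and the range set wide. The estimate for compound 4 is 6500 ng.h/mL, between 2000 ng.h/mL and 22000 ng.h/mL.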

Compound 4, area under the concentration-time curve: 489 ng.h/mL
Compound 4: middle estimate off by 13-fold (1.12 log units), on the high side; measured number outside the range, below it.
By their numbers in this assay, from the lowest: compound 4; then compounds 3 and 1 (each within the scatter of the next); then compound 2.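

In this assay, trifluoromethyl is the only group shown at this position that is not an aromatic ring, and it gives a 10-fold lower number from compound 1 to compound 4 (1.00 log units; beyond the scatter), alongside a 9.7-fold lower number from compound 3 to compound 4 (0.99 log units; beyond the scatter) and a 63-fold lower number from compound 2 to compound 4 (1.80 log units; beyond the scatter). The earlier steps shown here only compared six-membered aromatic rings at this position; now each of the three compounds carrying such a ring stands beyond the scatter above compound 4, and the size of the drop depends on which ring leaves. Nothing available on these compounds accounts for the drop.

The compounds shown cannot separate the loss of the aromatic ring from the arrival of trifluoromethyl itself. From the compounds shown here alone, it also remains open how a methyl, an amine or a saturated ring such as cyclohexyl would read at this position.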